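The source may hold more compounds than are shown below. What is called first, only, known or untested is meant among the compounds shown, and "the series" means these compounds.

In a functional assay on SK-OV-3 cells (Homo sapiens) for inhibition, read by CCK-8 assay, with a stated time of 70 h (a higher number here means a weaker inhibitor, a lower number a stronger inhibitor), compound 1 `COc1ccc(OCCOCCNC2CCCC2)cc1` gives 99100 nM, the highest of the two numbers recorded so far. Compound 3 `c1ccc2cc(OCCOCCNC3CCCC3)ccc2c1` gives 40600 nM, a value below that of compound 1 by more than the usual scatter. Compound 2 `c1ccc(COc2ccc(OCCOCCNc3ccccc3)cc2)cc1` is reported only as a limit, > 100000 nM, and not as a number. Compound 4 `Cc1ccc(COc2ccc(OCCOCCNC3CCCC3)cc2)cc1` has not yet been measured; it differs from compound 1 by 4-methylphenyl in place of hydrogen on a saturated chain carbon bound to an oxygen on an aromatic ring. Among the measured compounds shown here, no pair of measured compounds differs by this change alone, so the step from compound 1 to compound 4 in this assay is expected to be small, at most a modest lowering and possibly nothing beyond the scatter. Compound 4 is therefore estimated at 70000 nM, between 25000 nM and 200000 nM. That amounts to an expected step of a 1.4-fold lower number from compound 1 to compound 4 (0.15 log units; within the scatter).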

Compound 4, half-maximal inhibitory concentration: 17200 nM
Compound 4: the middle estimate sits 4.1-fold (0.61 log units) above what was measured, and the stated range ends above it.
By their numbers in this assay, from the lowest: compound 4; then compound 3; then compound 1. At a limit, above all of these: compound 2.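

In this assay, the change of methyl to 4-methylbenzyl on the oxygen gives a 5.8-fold lower number from compound 1 to compound 4 (0.76 log units; beyond the scatter). Among the compounds shown here, this shows that the position accepts a whole aromatic ring, and that the larger group goes with a lower number, which no earlier pair could show. Compound 1 lies close to the top of what this assay reports, so this step starts from a value near the limit: the limit of > 100000 nM in this assay, at which 1 of the 4 values shown sits.

From the compounds shown here alone, whether the ring alone is enough, or its methyl also counts, remains open. So does the effect of a carboxylic acid or an amine in place of that methyl.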